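The compounds below may be only part of what the source reports. "The series", "measured", "known", "first", "only" and "open" are said of these compounds alone.

In an ADME assay on Vero cells (Chlorocebus sabaeus) for cytotoxicity, with a stated time of 5 days (a higher number here means that more compound is tolerated, a lower number that less compound is tolerated), compound 1 (`COc1nc(Cl)nc2c1ncn2[C@@H]1O[C@H](CO)[C@@H](O)[C@@]1(C)O`) sits at > 100000 nM which is a limit of the assay and not a number. Within the data shown here, compound 2 (`C[C@@]1(OC(=O)c2ccccc2)[C@H](OC(=O)c2ccccc2)[C@@H](COC(=O)c2ccccc2)O[C@H]1n1cnc2c(N)nc(NO)nc21`) gives 42000 nM as the only actual number so far. Compound 3 (`C[C@@]1(OC(=O)c2ccccc2)[C@H](OC(=O)c2ccccc2)[C@@H](COC(=O)c2ccccc2)O[C@H]1n1cnc2c(Cl)nc(NO)nc21`) departs from compound 2 in one place (chloro in place of amino on an aromatic carbon) with chloro in place of amino on an aromatic carbon. Among the measured compounds shown here, no measured pair shows what this swap does, so only a moderate shift towards less compound tolerated is expected (a 2.8-fold lower number from compound 2 to compound 3 (0.45 log units; beyond the scatter)). In this assay the estimate for compound 3 is 15000 nM (expected range 4000 nM to 60000 nM).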

Compound 3, half-maximal cytotoxic concentration: > 100000 nM
Compound 3: only a limit was reported (the forecaster's own chance of this, stated with the estimate: 15%); middle value at least 6.6-fold (0.82 log units) away from the limit.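

In this assay, chloro in place of amino on an aromatic carbon, next to the ring nitrogen, gives an at least 2.3-fold higher number from compound 2 to compound 3 (0.37 log units; beyond the scatter). This shows that the group at this position matters in this assay, with more compound tolerated once amino gives way to chloro. The full size of the step cannot be read because compound 3 sits at a limit: the limit of > 100000 nM in this assay, at which 2 of the 3 values shown sit.

On these data alone, how fluoro, bromo or a dimethylamino group would behave at this position remains open. So does whether the same swap would have the same effect with free hydroxyl groups on the sugar.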